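The compounds below may be only part of what the source reports. "The series", "measured", "known", "first", "only" and "open" are said of these compounds alone.

In a functional assay on HL-60 cells (Homo sapiens) for cytotoxicity, read by WST assay, with a stated time of 48 h (a higher number here means that more compound is needed for the effect, a lower number that less compound is needed), compound 3 (`Cc1ccccc1C[C@H]1COC(=O)[C@@H]1Cc1ccc(Cl)c(Cl)c1`) gives 22000 nM, compound 1 (`CCOc1ccccc1C[C@H]1COC(=O)[C@@H]1Cc1ccc(Cl)c(Cl)c1`) gives 15000 nM and compound 2 (`CCCCOc1ccccc1C[C@H]1COC(=O)[C@@H]1Cc1ccc(Cl)c(Cl)c1`) gives 10000 nM. Compound 4 (`COc1cccc(C[C@H]2COC(=O)[C@@H]2Cc2ccc(Cl)c(Cl)c2)c1`) carries 3-methoxyphenyl in place of 2-methylphenyl on a saturated chain carbon bound to a saturated ring carbon. The nearest evidence is a 1.5-fold higher number from compound 1 to compound 3 (0.17 log units; within the scatter), together with a 2.2-fold higher number from compound 2 to compound 3 (0.34 log units; beyond the scatter) and a 1.5-fold lower number from compound 1 to compound 2 (0.18 log units; within the scatter). The first and last lie within the scatter, and the middle one is modest. Going by the values given here, no measured compound carries 3-methoxyphenyl, so these steps bear only indirectly, and no step beyond the scatter is expected. The expected step is a 1.4-fold lower number from compound 3 to compound 4 (0.14 log units; within the scatter). For compound 4 the estimated value is 16000 nM, with an expected range of 8000 nM to 32000 nM.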

Compound 4, half-maximal effective concentration: 34000 nM
Compound 4: middle estimate off by 2.1-fold (0.33 log units), on the low side, and the stated range ends below it.
By their numbers in this assay, from the lowest: compounds 2, 1, 3 and 4 (each within the scatter of the next, the first and the last beyond it).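

In this assay, the swap of 2-methylphenyl for 3-methoxyphenyl on a saturated chain carbon bound to a saturated ring carbon stays within the scatter (a 1.5-fold higher number from compound 3 to compound 4 (0.19 log units; within the scatter)). This place therefore tolerates an aryl group that differs from 2-methylphenyl in both substituent and its name's ring numbering, including the added hydrogen-bond acceptor, without a step beyond the scatter. No evidence available here bears on this result. Still open, as far as these compounds go, is whether an amine or a carboxylic acid in place of the methoxy group would give a step beyond the scatter.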